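The source may report more compounds than this note shows. Statements on the series, on what has been measured and on what is new or still open speak of the compounds shown alone.

Measured compounds:
Compound 1, `Clc1ccc(COc2ccccc2/C=C/C(/C=C/c2ccccn2)=N/Oc2ncnc3cc(Cl)ccc23)c(Cl)c1`: in a functional assay on SMMC-7721 cells (Homo sapiens) for inhibition, read by MTT assay, with a stated time of 72 h, tested at 1 uM (a higher number here means a stronger effect of the compound at the concentration tested, a lower number a weaker effect), compound 1 gives 23.6%.
Compound 2, `Cc1cccc2ncnc(O/N=C(\C=C\c3ccccn3)/C=C/c3ccccc3OCc3ccc(Cl)cc3Cl)c12`: in this assay compound 2 gives 90.8%.

Within the data shown here, compound 2 stands highest of the two numbers measured so far; its nearest neighbour is compound 1, and the difference between them, a number 67.2 percentage points higher from compound 1 to compound 2 (beyond the scatter), lies beyond the scatter. Compound 3, `Clc1ccc(COc2ccccc2/C=C/C(/C=C/c2ccccn2)=N/Oc2ncnc3ccccc23)c(Cl)c1`, has not yet been measured. It differs from compound 2 in one place: hydrogen in place of methyl on an aromatic carbon.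

Among the measured compounds shown here, only one measured step exists, and it bears on this change only in part: the move from compound 1 to compound 2 replaces a 7-chloroquinazolin-4-yl with a 5-methylquinazolin-4-yl, so it alters the same ring system at two places at once, whereas compound 3 merely loses the methyl. That step was large, which shows the read-out in this assay is sensitive to substitution on this ring system, but the data give no separate measure of the methyl alone. A loss of some size, in the downward direction, is therefore expected, with wide uncertainty: the step is estimated as a number 35.8 percentage points lower from compound 2 to compound 3 (beyond the scatter). Compound 3 is expected to give about 55%, within a range from 20% to 88%.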

Compound 3, a percentage reported as inhibition, at one concentration (the size of the read-out at that concentration, not a potency): 33.3%
Compound 3: the middle estimate sits 21.7 percentage points above what was measured; the range from low to high includes it.
By their numbers in this assay, from the lowest: compounds 1 and 3 (each within the scatter of the next); then compound 2.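

Taken alone in this assay, the change from 5-methylquinazolin-4-yl to quinazolin-4-yl gives a number 57.5 percentage points lower from compound 2 to compound 3 (beyond the scatter) and so isolates what the earlier step, a number 67.2 percentage points higher from compound 1 to compound 2 (beyond the scatter), could not, since that step changed two places at once: the single methyl, on an aromatic carbon ortho to a fused ring and meta to a fused ring, separates compound 2 from compound 3 by a large margin. The other single change, the chloro of compound 1 giving way to hydrogen, gives a number 9.7 percentage points higher from compound 1 to compound 3 (within the scatter), so the chloro of compound 1 and the hydrogen of compound 3 cannot be told apart here, and among these three compounds only the methyl compound, compound 2, stands apart from the others. The data hold no measurement that accounts for the effect of the methyl.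

Still open, from the compounds shown here alone, is whether the effect belongs to methyl itself or would carry over to an ethyl, a methoxy or a chloro at the same place, and whether a methyl at the place of the chloro in compound 1 would do the same. Since every number here is a read-out at one concentration, the compounds also leave open how the size of their effects would compare at other concentrations.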